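The source may report more compounds than this note shows. Statements on the series, on what has been measured and on what is new or still open speak of the compounds shown alone.

Working notes on the urea series sharing the core of compound 1 `COC(=O)c1ccc2c(ccn2-c2ccc(NC(=O)Nc3ccc(Cl)c(C(F)(F)F)c3)cc2)n1`. In a functional assay on A375P cells (Homo sapiens) for cytotoxicity, read by MTT assay (on this read-out higher numbers stand for weaker inhibition and lower numbers for stronger inhibition), compound 1 gives 3600 nM. Compound 2 `COC(=O)c1ccc2c(ccn2-c2ccc(NC(=O)Nc3cccc(Cl)c3Cl)cc2)n1` gives 6400 nM in this assay, and compound 3 `COC(=O)c1ccc2c(ccn2-c2ccc(NC(=O)Nc3ccc(Cl)c(Cl)c3)cc2)n1` gives 3800 nM. Among these three compound 1 carries the lowest number, but its steps to the other two are small: a 1.8-fold higher number from compound 1 to compound 2 (0.25 log units; within the scatter) and a 1.1-fold higher number from compound 1 to compound 3 (0.02 log units; within the scatter). Likewise a 1.7-fold lower number from compound 2 to compound 3 (0.23 log units; within the scatter). All three measured compounds therefore sit within the scatter of one another, and no order among them can be read from the numbers.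

Compound 4 `NC(=O)c1ccc2c(ccn2-c2ccc(NC(=O)Nc3ccc(Cl)c(C(F)(F)F)c3)cc2)n1` departs from compound 1 at the other end of the molecule: amino in place of methoxy on a carbonyl carbon. Going by the values given here, none of the measured steps touches this place; each of them exchanges the aryl group on the urea nitrogen and leaves the methoxycarbonyl untouched. The three steps seen so far were all within the scatter, so the series has so far given no step beyond it in this assay, but that says nothing about the ester end. Among the compounds with values here, with no comparable step in the data, no direction is expected for the change from compound 1 to compound 4, and the step is estimated as a 1.1-fold higher number from compound 1 to compound 4 (0.05 log units; within the scatter), with a wide range reflecting the absence of a precedent. Compound 4 is therefore expected to give about 4000 nM in this assay, estimated between 1300 nM and 12000 nM.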

Compound 4, half-maximal inhibitory concentration: 9900 nM
Beside the measured number, compound 4's estimate is 2.5-fold (0.39 log units) below it; low and high end bracket the measured number.
By their numbers in this assay, from the lowest: compounds 1, 3, 2 and 4 (each within the scatter of the next, the first and the last beyond it).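

The ester end responds in this assay where the aryl end has not: amino in place of methoxy on a carbonyl carbon gives a 2.8-fold higher number from compound 1 to compound 4 (0.44 log units; beyond the scatter), a modest step but the only one in the series that lies beyond the scatter. Going by these compounds alone, the exchanges of the aryl group on the urea nitrogen among compound 1, compound 2 and compound 3 all stayed within the scatter, so this position is the first place where a single change moves the number clearly, and it moves it towards weaker inhibition. No measurement at hand bears on the reason for this step, so the change from methoxycarbonyl to carbamoyl stands here as an observation only.

Going by these compounds, with a single pair at this position, it remains open whether other groups on the carbonyl carbon, such as a carboxylic acid, an ethoxycarbonyl or a methyl-substituted carbamoyl, would stay with compound 1 or move with compound 4. On these data alone, it is equally open whether the same exchange would give a step of similar size on the 3,4-dichlorophenyl or 2,3-dichlorophenyl ureas.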